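Methoxy for fluoro on the compound 2 scaffold

A few compounds are considered here, and "the series" means these few. Any claim that something is new, unique, unknown or untested is made for them only; others in the source may bear on it.

Measured in a functional assay on A549 cells (Homo sapiens) for cytotoxicity, read by WST assay, with a stated time of 48 h (a higher number here means a weaker inhibitor, a lower number a stronger inhibitor), so far:
- compound 1 `COc1ccc2c(/C=C(\C#N)C(=O)c3c[nH]c4cc(F)ccc34)c[nH]c2c1` gives 5500 nM
- compound 2 `N#C/C(=C\c1c[nH]c2cc(F)ccc12)C(=O)c1c[nH]c2cc(F)ccc12` gives 36100 nM
- compound 3 `COc1ccc2[nH]cc(C(=O)/C(C#N)=C/c3c[nH]c4cc(F)ccc34)c2c1` gives > 50000 nM (a limit of the assay, not a number)

Of the two true numbers, compound 2 holds the higher, at 36100 nM in this assay, with compound 1 the nearest. Compound 3 reports only a limit. The record therefore contains the limit of > 50000 nM in this assay, at which 1 of the 3 values shown sits, and no number for that compound.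

Compound 4 `COc1ccc2c(C(=O)/C(C#N)=C/c3c[nH]c4cc(F)ccc34)c[nH]c2c1` is the next case. Its difference from compound 2 is methoxy in place of fluoro on an aromatic carbon of a six-membered aromatic ring of carbon only, meta to a fused ring and para to a fused ring.

Among the compounds with values here, one measured step bears on this exchange: a 6.6-fold higher number from compound 1 to compound 2 (0.82 log units; beyond the scatter). It runs in the opposite sense and sits on a different aromatic carbon, so it is only a loose guide. Compound 3 also carries a methoxy and stays at the limit > 50000 nM, which goes against any rule that methoxy lowers the number.

A modest move to a lower number is expected, smaller than the compound 1 step, with the estimate being a 2.6-fold lower number from compound 2 to compound 4 (0.41 log units; beyond the scatter) in this assay as the expected change. For compound 4 the estimate is 14000 nM, with an expected range from 4000 nM to 45000 nM as its ends.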

Compound 4, half-maximal inhibitory concentration: 800 nM
Compound 4: middle estimate off by 18-fold (1.24 log units), on the high side, and the stated range ends above it.
By their numbers in this assay, from the lowest: compound 4; then compound 1; then compound 2. At a limit, above all of these: compound 3.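

In this assay, the place on the six-membered aromatic ring of carbon only, meta to a fused ring and para to a fused ring, responds strongly to this exchange: methoxy in place of fluoro gives a 45-fold lower number from compound 2 to compound 4 (1.65 log units; beyond the scatter). Together with a 6.6-fold higher number from compound 1 to compound 2 (0.82 log units; beyond the scatter), which concerns a different aromatic carbon, this gives two cases in which the methoxy compound carries the lower number, so the preference for methoxy over fluoro is not confined to one place on the core. It does not extend to every methoxy compound, as compound 3 goes against the pattern, with a value that is a limit of the assay and not a number: the limit of > 50000 nM in this assay, at which 1 of the 4 values shown sits.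

The compounds shown compare only fluoro and methoxy at this place, so they do not separate a gain from methoxy entering from a loss from fluoro leaving, a question that the same core with plain hydrogen there would address. Going by these compounds, whether the trend continues with a longer chain such as ethoxy, or changes with a hydroxyl or an amine at this place, remains open.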